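The compounds below may be only part of what the source reports. "The series", "measured", "known", "first", "only" and "open" are said of these compounds alone.

Measured compounds in an ADME assay on Caco-2 cells (Homo sapiens) for permeability, read by LC-MS, in the apical to basolateral direction, with a stated time of 60 min, at pH 6.5; a higher number here means that the compound crosses the layer faster, a lower number that the compound crosses the layer more slowly:
compound 1, `CC(C)(C)[C@@H](O)C(=O)N1CCS[C@H]1C(=O)NCc1cc(Cl)ccc1-n1cnnn1`, gives 5.2 10^-6 cm/s
compound 2, `CC(C)(C)[C@@H](O)C(=O)N1C[C@@H]2C[C@@H]2[C@H]1C(=O)NCc1cc(Cl)ccc1-n1cnnn1`, gives 17 10^-6 cm/s
compound 3, `O=C([C@H](O)c1ccccc1)N1CC[C@@H]2C[C@@]21C(=O)NCc1cc(Cl)ccc1-n1cnnn1`, gives 2.6 10^-6 cm/s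

Compound 2 stands highest of the three numbers. Its nearest neighbour is compound 1, whose value sits lower by more than the scatter, and compound 3 sits further below, also beyond the scatter. None of these three pairs differs in a single place, so the numbers only show where each compound sits and not what any one change does.

Compound 4, `O=C(NCc1cc(Cl)ccc1-n1cnnn1)[C@@H]1[C@H]2C[C@H]2CN1C(=O)[C@H](O)C1CCCCC1`, is not yet measured in this assay. Against compound 2 the change is cyclohexyl in place of tert-butyl on a saturated chain carbon bound to a carbonyl carbon and an oxygen on a saturated carbon. Among the measured compounds shown here, no measured pair carries this change, so nothing in the data fixes its size or its direction. The expected step is a 1.1-fold lower number from compound 2 to compound 4 (0.05 log units; within the scatter), none beyond the scatter, as the shown values give no ground for a larger move either way. Compound 4 is accordingly estimated at 15 10^-6 cm/s, with a range from 7 10^-6 cm/s to 30 10^-6 cm/s.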

Compound 4, apparent permeability: 25 10^-6 cm/s
For compound 4 the middle estimate is 1.7-fold (0.22 log units) below the measured one, within the range that was stated.
By their numbers in this assay, from the lowest: compounds 3 and 1 (each within the scatter of the next); then compounds 2 and 4 (each within the scatter of the next).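

In this assay, cyclohexyl in place of tert-butyl on a saturated chain carbon bound to a carbonyl carbon and an oxygen on a saturated carbon gives a 1.5-fold higher number from compound 2 to compound 4 (0.17 log units; within the scatter). Among the compounds shown here, this is the first step that can be read at a single place, and it shows that the read-out does not separate these two groups at this position on the core of compound 2. No measurement at hand bears on why the result falls as it does.

From the compounds shown here alone, both groups compared here are made of carbon only, so how a group carrying an amine or a carboxylic acid at this position would read in this assay stays open. Also open, going by these compounds, is whether the same change would read alike on the core of compound 1 or the core of compound 3.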